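The source may report more compounds than this note shows. Statements on the series, on what has been measured and on what is new or still open speak of the compounds shown alone.

Among the three measured compounds, compound 3 `Fc1ccc(C2CC(c3ccc(Cl)s3)=NN2c2nc(-c3ccc(Br)cc3)cs2)cc1` is the only one that gives an actual number in a functional assay on A549 cells (Homo sapiens) for antiproliferative activity, read by XTT assay, with a stated time of 24 h; a higher number here means a weaker inhibitor, a lower number a stronger inhibitor: compound 3 gives 62.5 ug/mL. Compound 1 `Cc1ccc(C2=NN(c3nc(-c4ccccc4)cs3)C(c3ccc(F)cc3)C2)s1` returns only a limit of the assay, > 500 ug/mL. Compound 2 `Cc1ccc(C2=NN(c3nc(-c4ccc(Br)cc4)cs3)C(c3ccc(F)cc3)C2)s1` likewise returns only a limit, > 500 ug/mL. Among the compounds with values here, the single readable step, from compound 2 to compound 3, is an at least 8.0-fold lower number from compound 2 to compound 3 (0.90 log units; beyond the scatter), but it concerns the group on the thiophene and not the change considered here.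

Compound 4 `Fc1ccc(C2CC(c3ccc(Cl)s3)=NN2c2nc(-c3ccccc3)cs2)cc1` differs from compound 3 in one place: hydrogen in place of bromo on an aromatic carbon. Within the data shown here, the one measured step that bears on this change runs the other way, from compound 1 to compound 2, and is a step that the two limits leave unreadable from compound 1 to compound 2 because both compounds sit at the limit of > 500 ug/mL in this assay, at which 2 of the 3 values shown sit. Going by these compounds, its size and direction therefore stay unknown, and the expectation for compound 4 rests on a wide range. Taking the bromine away is expected to give a 2.4-fold higher number from compound 3 to compound 4 (0.38 log units; beyond the scatter). Compound 4 is estimated at 150 ug/mL in this assay, within a range from 40 ug/mL to 500 ug/mL, with a real chance that only a limit is reported.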

Compound 4, half-maximal inhibitory concentration: > 500 ug/mL
Compound 4 gave a limit, no number (the forecaster's own chance of this, stated with the estimate: 35%); at least 3.3-fold (0.52 log units) between middle value and limit.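

In this assay, the 4-bromophenyl to phenyl change gives an at least 8.0-fold higher number from compound 3 to compound 4 (0.90 log units; beyond the scatter), so this place on the six-membered ring matters when chloro is present on the other side of the shared core. Among the compounds shown, only compound 3 carries both bromo and chloro and only compound 3 gives a number, while compound 2 with bromo alone and compound 4 with chloro alone both stop at a limit of the assay. The steps from compound 1 to compound 2 and from compound 1 to compound 4 cannot be read, because each pair sits at the same limit: the limit of > 500 ug/mL in this assay, at which 3 of the 4 values shown sit.

Going by these compounds, the full size of the loss on removing bromo stays open, since compound 4 gives only a limit. Also open, on these data alone, is whether another group at this place, such as chloro, methoxy or an amine, could stand in for bromo.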